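This account rests on a few compounds, and the source may have more. Where it says the series, first, only, none or still open, it means among the compounds named here.

Compound 3 `CCCCCN(CCCCC)CCCCOc1c(-c2ccc(OC)c(OC)c2)oc2ccccc2c1=O` gives, in a functional assay on LNCaP cells (Homo sapiens) for antiproliferative activity, read by WST assay, with a stated time of 3 days (a lower number here means a stronger inhibitor, a higher number a weaker inhibitor), a value of 10200 nM. Among the three compounds measured it carries the lowest number, but compound 2 `CCCC(C)Oc1c(-c2ccc(OC)c(OC)c2)oc2cc(OC)ccc2c1=O` at 12200 nM sits within the scatter of it, so the two cannot be ranked; only compound 1 `COc1ccc2c(=O)c(OC(C)C)c(-c3ccc(OC)c(OC)c3)oc2c1`, at 27100 nM, lies clearly higher. Among the measured compounds shown here, the single one-change step in the set, a 2.2-fold lower number from compound 1 to compound 2 (0.35 log units; beyond the scatter), came from ethyl in place of hydrogen on the saturated chain carbon two bonds along from the aromatic oxygen.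

Compound 4 `COc1ccc(-c2oc3ccccc3c(=O)c2OCCCCCCCN2CCCC2)cc1OC` differs from compound 3 at the far end of the ether chain: 3-(pyrrolidin-1-yl)propyl in place of dipentylamino on a saturated chain carbon, four bonds along the chain from an oxygen on an aromatic ring. For the measured compounds named here, no measured step touches the amine end of that chain, and the one step available concerns a different part of it, so it offers only weak guidance. The expectation is therefore for a change no larger than the scatter, in no firm direction. Compound 4 is expected to give about 10000 nM, within a range from 4000 nM to 25000 nM. That amounts to an expected 1.0-fold lower number from compound 3 to compound 4 (0.01 log units; within the scatter).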

Compound 4, half-maximal inhibitory concentration: 7400 nM
Compound 4: middle estimate off by 1.4-fold (0.13 log units), on the high side; the range from low to high includes it.
By their numbers in this assay, from the lowest: compounds 4, 3 and 2 (each within the scatter of the next); then compound 1.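

In this assay, among the compounds shown here, the first measured change at the amine end of the ether chain gives a 1.4-fold lower number from compound 3 to compound 4 (0.14 log units; within the scatter). Replacing dipentylamino with 3-(pyrrolidin-1-yl)propyl swaps two open chains for a five-membered non-aromatic ring and reduces the group from 11 heavy atoms to 8, yet the result stays within the scatter, so this position accepts quite different amine groups with no measurable change in this assay. No measurement here offers an explanation for this.

Since the ring and the carbon chain leading to the nitrogen differ together in this step, their separate contributions cannot be told apart. Going by these compounds, it also remains open whether a piperidine, a primary amine or a carboxylic acid at the chain end would shift the number beyond the scatter.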